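Aryl swap on the shared core: compound 3 to compound 4

This account rests on a few compounds, and the source may have more. Where it says the series, first, only, none or still open, it means among the compounds named here.

compound 1 `COc1cc(-n2cnc3ccc(-c4ccc([N+](=O)[O-])cc4)cc32)cc(OC)c1OC`: 8940 nM in a functional assay on A549 cells (Homo sapiens) for antiproliferative activity, read by MTT assay, with a stated time of 72 h; a lower number here means a stronger inhibitor, a higher number a weaker inhibitor
compound 2 `COc1ccc(-c2ccc3ncn(-c4cc(OC)c(OC)c(OC)c4)c3c2)cc1`: > 10000 nM
compound 3 `COc1cc(-n2cnc3ccc(-c4ccc(C)cc4F)cc32)cc(OC)c1OC`: > 10000 nM

Compound 3 stands only as a limit of this assay, and two of the three values sit there (the limit of > 10000 nM in this assay, at which 2 of the 3 values shown sit). The measured steps of an at least 1.1-fold higher number from compound 1 to compound 2 (0.04 log units; that floor lies within the scatter) and an at least 1.1-fold higher number from compound 1 to compound 3 (0.04 log units; that floor lies within the scatter) are floors within the scatter.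

Compound 4 `CCOc1ccc(-c2ccc3ncn(-c4cc(OC)c(OC)c(OC)c4)c3c2)cc1` differs from compound 3 by 4-ethoxyphenyl in place of 2-fluoro-4-methylphenyl on an aromatic carbon. The step that bears on it, a step that the two limits leave unreadable from compound 2 to compound 3, is unreadable; compound 2, which carries the 4-methoxyphenyl closest to the entering 4-ethoxyphenyl, sits at the limit. Compound 4 is therefore expected to stay near that limit, with the estimated step that the limit leaves unreadable from compound 3 to compound 4 not readable beyond the scatter. The estimate for compound 4 is 15000 nM, between 6000 nM and 40000 nM.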

Compound 4, half-maximal inhibitory concentration: 8550 nM
Compound 4: middle estimate off by 1.8-fold (0.24 log units), on the high side; low and high end bracket the measured number.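

In this assay, 4-ethoxyphenyl gives this position a second readable number, and the ethoxy-for-nitro change shows a 1.0-fold lower number from compound 1 to compound 4 (0.02 log units; within the scatter). Against the two compounds at the limit, only floors can be read: an at least 1.1-fold lower number from compound 3 to compound 4 (0.06 log units; that floor lies within the scatter), and an at least 1.1-fold lower number from compound 2 to compound 4 (0.06 log units; that floor lies within the scatter). No step at this position yet leaves the scatter, and some of the values remain limits: the limit of > 10000 nM in this assay, at which 2 of the 4 values shown sit.

Going by these compounds, it remains open whether an amine or a carboxylic acid on this phenyl, or a chain longer than ethoxy, would move the number beyond the scatter.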